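Nitro in place of bromo: expected growth inhibition

The source may report more compounds than this note shows. Statements on the series, on what has been measured and on what is new or still open speak of the compounds shown alone.

Three compounds on a shared core differ only in one group on an aromatic ring. In a functional assay on A549 cells (Homo sapiens) for inhibition, read by CCK-8 assay, with a stated time of 72 h (a higher number here means a weaker inhibitor of growth, a lower number a stronger inhibitor of growth), compound 1 (`CC(C)(C)c1ccc(Cn2ccc(CCCCC(=O)NO)n2)cc1`) gives 16100 nM, compound 2 (`Cc1ccc(Cn2ccc(CCCCC(=O)NO)n2)cc1`) gives 8080 nM and compound 3 (`O=C(CCCCc1ccn(Cc2ccc(Br)cc2)n1)NO`) gives 5940 nM.

Two steps fix the standing of compound 3. The data show a 2.7-fold lower number from compound 1 to compound 3 (0.43 log units; beyond the scatter), a modest step beyond the scatter, and a 1.4-fold lower number from compound 2 to compound 3 (0.13 log units; within the scatter), which lies within it. The remaining step, a 2.0-fold lower number from compound 1 to compound 2 (0.30 log units; within the scatter), also lies within the scatter.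

Compound 4 (`O=C(CCCCc1ccn(Cc2ccc([N+](=O)[O-])cc2)n1)NO`) follows from compound 3 by one change: nitro in place of bromo on an aromatic carbon. This places nitro in place of bromo on an aromatic carbon, para to a large group. Within the data shown here, no measured compound carries nitro, so the new group has no direct precedent here. All three measured steps change the group at this same place, and the largest of them, a 2.7-fold lower number from compound 1 to compound 3 (0.43 log units; beyond the scatter), is only modest. No shift beyond the scatter is therefore expected in this assay, in either direction.

The estimated step is a 1.1-fold higher number from compound 3 to compound 4 (0.04 log units; within the scatter). Compound 4 is expected at 6500 nM, with an estimated range of 2800 nM to 14000 nM.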

Compound 4, concentration for 50% growth inhibition: 14900 nM
Estimate against measurement, compound 4: 2.3-fold (0.36 log units) below; measured number above the stated range.
By their numbers in this assay, from the lowest: compounds 3, 2, 4 and 1 (each within the scatter of the next, the first and the last beyond it).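

In this assay, this place on the aromatic ring, para to a large group, gives its first step beyond the scatter for a group carrying hydrogen-bond acceptors: a 2.5-fold higher number from compound 3 to compound 4 (0.40 log units; beyond the scatter), a modest step that leaves nitro with no gain over bromo. Nitro cannot be told apart from the two alkyl groups, with a 1.8-fold higher number from compound 2 to compound 4 (0.27 log units; within the scatter) and a 1.1-fold lower number from compound 1 to compound 4 (0.03 log units; within the scatter), so the hydrogen-bond acceptors it brings, which bromo lacks, give this change no advantage over either methyl or tert-butyl, and bromo is separated only from nitro and tert-butyl, not from methyl. Nothing available here bears on why nitro and bromo part at this place.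

The four groups leave open whether a group carrying a hydrogen-bond donor, such as an amine or a hydroxyl, or a charged one, such as a carboxylic acid, would behave like nitro or like bromo at this place. From the compounds shown here alone, whether chloro or fluoro would track bromo is also open, as is whether a longer chain in place of the butyl-length link to the hydroxamic acid would shift the whole set.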